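The source may report more compounds than this note shows. Statements on the series, on what has been measured and on what is new or still open speak of the compounds shown alone.

Measured compounds:
compound 1 `Oc1cccc(-c2cc(-c3ccco3)cc(-c3ccccc3O)n2)c1` — 1790 nM
compound 2 `Oc1ccc(-c2cc(-c3ccco3)cc(-c3ccccc3O)n2)cc1` — > 50000 nM
compound 3 `Oc1cccc(-c2cc(-c3ccoc3)cc(-c3cccc(O)c3)n2)c1` — 1650 nM

In a functional assay on DU-145 cells (Homo sapiens) for cytotoxicity, read by CCK-8 assay (a higher number here means a weaker inhibitor, a lower number a stronger inhibitor), compound 1 gives 1790 nM and compound 3 gives 1650 nM; the two sit within the scatter of each other. Compound 2 reaches only the limit of this assay, > 50000 nM, and no number. The step of an at least 27-fold higher number from compound 1 to compound 2 (1.44 log units; beyond the scatter) is the change (4-hydroxyphenyl in place of 3-hydroxyphenyl on an aromatic carbon); it rests on (the limit of > 50000 nM in this assay, at which 1 of the 3 values shown sits). The difference between the cores of compound 1 and compound 3 is not broken down here.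

Compound 4 `Oc1ccc(-c2cc(-c3ccoc3)cc(-c3cccc(O)c3)n2)cc1` is not yet measured. It differs from compound 3 by 4-hydroxyphenyl in place of 3-hydroxyphenyl on an aromatic carbon, the same kind of change as from compound 1 to compound 2, though the place differs: in compound 1 it is meta to a 2-hydroxyphenyl group and meta to a furan-2-yl group, in compound 3 meta to a 3-hydroxyphenyl group and meta to a furan-3-yl group. Given an at least 27-fold higher number from compound 1 to compound 2 (1.44 log units; beyond the scatter), a large step of a 27-fold higher number from compound 3 to compound 4 (1.44 log units; beyond the scatter) is expected in this assay, and a limit rather than a number is a real possibility. For compound 4 the estimate in this assay is 45000 nM, with a range from 10000 nM to 200000 nM.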

Compound 4, half-maximal inhibitory concentration: 2700 nM
Compound 4: middle estimate off by 17-fold (1.22 log units), on the high side; measured number below the stated range.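

In this assay the exchange of 3-hydroxyphenyl for 4-hydroxyphenyl gives a 1.6-fold higher number from compound 3 to compound 4 (0.21 log units; within the scatter), so the size of the step does not carry over from one core to the other: the same change on two cores in this assay, an at least 27-fold higher number (1.44 log units; beyond the scatter) from compound 1 to compound 2 and a 1.6-fold higher number (0.21 log units; within the scatter) from compound 3 to compound 4, at least 17-fold (1.23 log units) apart, beyond the scatter of two such steps

Compound 2 stands at a limit and not a number, so the earlier step has no upper end: the limit of > 50000 nM in this assay, at which 1 of the 4 values shown sits.

The two cores differ in more than one group (2-hydroxyphenyl against 3-hydroxyphenyl, furan-2-yl against furan-3-yl), so these two pairs do not show which of those differences goes with the gap, nor how the change behaves on any further core.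

Open, from the compounds shown here alone, is whether the gap follows the furan group or the second hydroxyphenyl group, which a core with only one of the two differences would separate. Also open, going by these compounds, is what a methoxy group or an amine would give in place of the hydroxyl on the exchanged ring, on either core.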